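Adding a chloro group to compound 2

A few compounds are considered here, and "the series" means these few. Any claim that something is new, unique, unknown or untested is made for them only; others in the source may bear on it.

Compound 1 (`O=C(Nc1ccc(Cl)c(Cl)c1)c1cc(F)ccc1O`) gives 760 nM
Compound 2 (`O=C(Nc1cccc(C(F)(F)F)c1)c1cc(F)ccc1O`) gives 1010 nM

Both values come from a functional assay on KG-1 cells (Homo sapiens) for cytotoxicity, read by luminescence and CellTiter-Glo, with a stated time of 3 days; on this read-out higher numbers stand for weaker inhibition and lower numbers for stronger inhibition. Compound 2 lies within the usual scatter of compound 1, so these two results cannot be told apart, and neither compound can be ranked above the other.

The next compound, compound 3 (`O=C(Nc1ccc(Cl)c(C(F)(F)F)c1)c1cc(F)ccc1O`), keeps the shared core of compound 2 and differs in one place: chloro in place of hydrogen on an aromatic carbon. Put simply, chloro takes the place of hydrogen on an aromatic carbon, ortho to a trifluoromethyl group and para to a large group.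

Within the data shown here, no measured pair isolates this change, so the evidence is indirect. Compound 1, which also carries chloro, gives 760 nM, within the scatter of compound 2 at 1010 nM. A large shift therefore seems unlikely. The expected change, a 1.7-fold lower number from compound 2 to compound 3 (0.23 log units; within the scatter), is small, leans towards stronger inhibition and may not pass the scatter. For compound 3 the estimate in this assay is 600 nM, with an expected range from 250 nM to 1300 nM.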

Compound 3, half-maximal inhibitory concentration: 540 nM
For compound 3 the middle estimate is 1.1-fold (0.05 log units) above the measured one; the measured number falls inside the stated range.
By their numbers in this assay, from the lowest: compounds 3, 1 and 2 (each within the scatter of the next).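

In this assay, chloro in place of hydrogen on an aromatic carbon, ortho to a trifluoromethyl group and para to a large group, gives a 1.9-fold lower number from compound 2 to compound 3 (0.27 log units; within the scatter). Among these compounds, this pair isolates the change directly for the first time and shows that, with trifluoromethyl present, adding chloro at this position does not produce a difference that can be told apart from the usual variation between repeats. A second one-place change, trifluoromethyl in place of chloro on an aromatic carbon, gives a 1.4-fold lower number from compound 1 to compound 3 (0.15 log units; within the scatter), so these two groups also cannot be separated on this read-out. Nothing in the information available explains these small differences.

The three compounds therefore show that this part of the molecule accepts chloro and trifluoromethyl without a clear shift, but they do not show how far that tolerance extends. From the compounds shown here alone, it remains open whether a different kind of group at the chloro position of compound 3, such as an amine, a carboxylic acid or a longer chain, would move the number beyond the scatter.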